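This account rests on a few compounds, and the source may have more. Where it says the series, first, only, none or still open, it means among the compounds named here.

Compound 1 `Nc1ccc(-c2cc(=O)c3c(N)c(F)c(N)c(F)c3o2)cc1F` gives 7.7 nM in a functional assay on MCF7 cells (Homo sapiens) for cytotoxicity, read by neutral red uptake, with a stated time of 3 days (a higher number here means a weaker inhibitor, a lower number a stronger inhibitor), the lowest of the three numbers. Compound 2 `CCOC(=O)c1c(F)c(N)c2c(=O)cc(-c3ccc(N)c(F)c3)oc2c1F` gives 1400 nM in this assay, the highest. Compound 3 `CCCCCC(=O)OCc1c(F)c(N)c2c(=O)cc(-c3ccc(N)c(F)c3)oc2c1F` gives 160 nM in this assay and stands second highest of the three: nearest to it is compound 2, with an 8.8-fold lower number from compound 2 to compound 3 (0.94 log units; beyond the scatter), and furthest is compound 1, with a 21-fold higher number from compound 1 to compound 3 (1.32 log units; beyond the scatter). Compound 4 `NCc1c(F)c(N)c2c(=O)cc(-c3ccc(N)c(F)c3)oc2c1F` differs from compound 3 by amino in place of (pentylcarbonyl)oxy on a saturated chain carbon bound to an aromatic carbon; the same difference, cut one bond further out, reads ((pentylcarbonyl)oxy)methyl to aminomethyl. Among the compounds with values here, two measured steps bear on this change. The step of a 180-fold higher number from compound 1 to compound 2 (2.26 log units; beyond the scatter) and the step of a 21-fold higher number from compound 1 to compound 3 (1.32 log units; beyond the scatter) both show that the ester-bearing groups carry a much higher number than amino on the aromatic carbon of compound 1, and the step of an 8.8-fold lower number from compound 2 to compound 3 (0.94 log units; beyond the scatter) shows that the two ester-bearing groups themselves differ modestly. Compound 4 keeps neither ester; it is therefore expected to move toward the number of compound 1, by an estimated 3.2-fold lower number from compound 3 to compound 4 (0.51 log units; beyond the scatter) in this assay. Compound 4 is expected to give about 50 nM in this assay, within a range from 10 nM to 300 nM.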

Compound 4, half-maximal inhibitory concentration: 26 nM
Compound 4: middle estimate off by 1.9-fold (0.28 log units), on the high side, and the stated range covers the measured number.
By their numbers in this assay, from the lowest: compound 1; then compound 4; then compound 3; then compound 2.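

In this assay the change of (pentylcarbonyl)oxy to amino on a saturated chain carbon bound to an aromatic carbon brings a 6.2-fold lower number from compound 3 to compound 4 (0.79 log units; beyond the scatter) and thus shows that the number at this position depends on what that chain carbon carries. The aminomethyl group also stands well apart from ethoxycarbonyl, with a 54-fold lower number from compound 2 to compound 4 (1.73 log units; beyond the scatter) on an aromatic carbon, yet it does not match amino itself, with a 3.4-fold higher number from compound 1 to compound 4 (0.53 log units; beyond the scatter) remaining beyond the scatter. Within the data shown here, the earlier compounds set only ester-bearing groups against amino here, so this is the first sign that an amine on the chain closes most of that gap but not all of it.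

No measurement shown here speaks to what lies behind these steps. From the compounds shown here alone, whether a hydroxymethyl, a dimethylaminomethyl or a longer aminoethyl chain at this position would come closer to compound 1 remains open.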